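Single Ring Back at the Aryl Position

The source may hold more compounds than are shown below. What is called first, only, known or untested is meant among the compounds shown, and "the series" means these compounds.

Compound 3 `c1ccc2c(-c3cn4ccnc4c(-c4ccc5ncn(C6CCCCC6)c5c4)n3)cccc2c1` stands lowest of the three measured compounds in a functional assay on SK-MEL-5 cells (Homo sapiens) for inhibition, read by sulforhodamine B assay, with a stated time of 48 h, tested at 10 uM (a lower number here means less inhibition, a higher number more inhibition at the concentration tested (going by the name of the read-out)), where compound 3 gives 4.06%. Compound 1 `Brc1cn2ccnc2c(-c2ccc3ncn(C4CCCCC4)c3c2)n1` gives 13.4%, and compound 2 `O=Cc1ccc(-c2cn3ccnc3c(-c3ccc4ncn(C5CCCCC5)c4c3)n2)cc1` gives 56.5%. Compound 4 `Fc1ccc(-c2cn3ccnc3c(-c3ccc4ncn(C5CCCCC5)c4c3)n2)cc1` differs from compound 3 by 4-fluorophenyl in place of naphthalen-1-yl on an aromatic carbon. Among the compounds with values here, two measured steps bear on this change: a number 52.4 percentage points lower from compound 2 to compound 3 (beyond the scatter), and a number 9.3 percentage points lower from compound 1 to compound 3 (within the scatter). Within the data shown here, the only group with one six-membered aromatic ring of carbon only gave the highest inhibition seen, so returning to such a ring is expected to raise the number, though compound 4 carries fluorine rather than the formyl group of compound 2, so a smaller rise is expected. For compound 4 the step of a number 25.9 percentage points higher from compound 3 to compound 4 (beyond the scatter) is expected. Compound 4 is estimated at 30%, within 5% to 60%.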

Compound 4, a percentage reported as inhibition, at one concentration (the size of the read-out at that concentration, not a potency): 7.36%
Estimate against measurement, compound 4: 22.6 percentage points above, and the stated range covers the measured number.
By their numbers in this assay, from the lowest: compounds 3, 4 and 1 (each within the scatter of the next); then compound 2.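

A single six-membered ring is not enough to bring the number back. In this assay, 4-fluorophenyl cannot be told apart from naphthalen-1-yl, with a number 3.3 percentage points higher from compound 3 to compound 4 (within the scatter), or from bromo, with a number 6 percentage points lower from compound 1 to compound 4 (within the scatter). The high number of compound 2 therefore goes with its formyl group and not with the ring alone, as fluoro in place of formyl gives a number 49.1 percentage points lower from compound 2 to compound 4 (beyond the scatter).

No measurement here says why the formyl group matters. On these data alone, whether a carboxylic acid or an amine in place of formyl would keep that inhibition remains open.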